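A few compounds are considered here, and "the series" means these few. Any claim that something is new, unique, unknown or untested is made for them only; others in the source may bear on it.

Compound 1 `O=C(CCc1ccc(C(F)(F)F)cc1)Nc1ccc2nc(N3CCC3)ccc2c1` gives 56 nM.
Compound 2 `CC(C)N(C)c1ccc2cc(NC(=O)CCc3ccc(C(F)(F)F)cc3)ccc2n1` gives 140 nM.
Compound 3 `O=C(CCc1ccc(C(F)(F)F)cc1)Nc1ccc2nc(N3CC4CC3CN4)ccc2c1` gives 490 nM.

These three values come from a functional assay on HEK293 cells for activation of melanin-concentrating hormone receptor 1 (Rattus norvegicus), read by inositol phosphate accumulation; on this read-out lower numbers stand for an effect already at smaller amounts and higher numbers for an effect only at larger amounts of compound. Compound 1 gives the lowest number of the three, so it acts at the smallest amount; compound 2 stands nearest to it and compound 3 furthest away, both beyond the scatter.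

The step to the unmeasured compound 4 `CN(c1ccc2cc(NC(=O)CCc3ccc(C(F)(F)F)cc3)ccc2n1)C1CCCC1` changes one group on the shared core: cyclopentyl(methyl)amino in place of azetidin-1-yl on an aromatic carbon. Going by the values given here, two measured steps bear on this. Swapping the four-membered ring for isopropyl(methyl)amino, a group with no ring, gave a 2.5-fold higher number from compound 1 to compound 2 (0.40 log units; beyond the scatter). Swapping it for a group of 7 heavy atoms with two five-membered rings gave an 8.8-fold higher number from compound 1 to compound 3 (0.94 log units; beyond the scatter). Between those two, a 3.5-fold higher number from compound 2 to compound 3 (0.54 log units; beyond the scatter) shows that the larger group at the same place moved the number further up. Compound 4 carries a methylamino group like compound 2, but with a five-membered non-aromatic ring of carbon only in place of isopropyl, so a step upward somewhat beyond that of compound 2 is expected, a 3.6-fold higher number from compound 1 to compound 4 (0.55 log units; beyond the scatter). The estimate for compound 4 is 200 nM, within a range from 70 nM to 600 nM.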

Compound 4, half-maximal effective concentration: 350 nM
Beside the measured number, compound 4's estimate is 1.8-fold (0.24 log units) below it; measured number inside the range.
By their numbers in this assay, from the lowest: compound 1; then compound 2; then compounds 4 and 3 (each within the scatter of the next).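

Ringing the carbon group on the amine nitrogen does not bring the number back down: cyclopentyl in place of isopropyl raises it further (a 2.5-fold higher number from compound 2 to compound 4 (0.40 log units; beyond the scatter)), and the azetidin-1-yl of compound 1 stays clearly lower (a 6.3-fold higher number from compound 1 to compound 4 (0.80 log units; beyond the scatter)). Two different groups of 7 heavy atoms, one with carbon only in its ring and one with a second nitrogen, now lie within the scatter of each other (a 1.4-fold lower number from compound 3 to compound 4 (0.15 log units; within the scatter)), so across these four compounds the number follows the heavy-atom count of the group, with no order readable between compound 3 and compound 4. Nothing here gives a measured reason for these steps.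

Still open, from the compounds shown here alone, is whether pyrrolidin-1-yl or dimethylamino would stay as low as azetidin-1-yl. A morpholine ring at this place would also test whether a ring oxygen fits the same trend.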